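The source may report more compounds than this note shows. Statements on the series, on what has been measured and on what is new or still open speak of the compounds shown alone.

Going by the values given here, in a functional assay on A2780 cells (Homo sapiens) for antiproliferative activity, read by MTT assay, with a stated time of 48 h (on this read-out lower numbers stand for stronger inhibition and higher numbers for weaker inhibition), compound 1 `COc1ccc(C(=O)c2ccc3c(c2)C=CC(C)(C)O3)c(NC(=O)CBr)c1` gives 1870 nM, the highest number of the three compounds measured so far. Compound 3 `COc1ccc(C(=O)c2ccc(OC)c3c2C=CC(C)(C)O3)c(NC(=O)CN)c1` gives 890 nM, and compound 2 `COc1ccc(C(=O)c2ccc(OC)c3c2OC(C)(C)C=C3)c(NC(=O)CN)c1` gives 380 nM. Both lie below compound 1 by more than the scatter. Compound 4 `COc1ccc(C(=O)c2ccc3c(c2)C=CC(C)(C)O3)c(NC(=O)CN)c1` has not yet been measured. It keeps the core of compound 1 and differs from it in one place: amino in place of bromo on a saturated chain carbon bound to a carbonyl carbon. Among the compounds with values here, no measured pair isolates this change, as compound 2 and compound 3 carry the amino group on cores that differ from that of compound 1. Even so, they offer the only guide, and a moderate step toward stronger inhibition is expected in this assay, with compound 3 at 890 nM as the closest reference. Compound 4 is estimated at 800 nM, within an expected range of 300 nM to 2100 nM. This estimate corresponds to an expected 2.3-fold lower number from compound 1 to compound 4 (0.37 log units; beyond the scatter).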

Compound 4, half-maximal inhibitory concentration: 590 nM
Compound 4: middle estimate off by 1.4-fold (0.13 log units), on the high side, and the stated range covers the measured number.
By their numbers in this assay, from the lowest: compounds 2, 4 and 3 (each within the scatter of the next, the first and the last beyond it); then compound 1.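

In this assay, going by these compounds alone, amino in place of bromo on a saturated chain carbon bound to a carbonyl carbon gives a 3.2-fold lower number from compound 1 to compound 4 (0.50 log units; beyond the scatter) and so forms the first pair that isolates this change. Within the data shown here, compound 2 and compound 3 carry the amino group on other cores, whereas here the core of compound 1 is held fixed and the single change alone moves the number beyond the scatter, a modest step toward stronger inhibition. Nothing available explains why this exchange has this effect.

The compounds shown leave open whether a dimethylamino group, a hydroxyl group or a longer aminoethyl chain at this place would give a lower or a higher number. They also leave open whether bromo and amino differ by a similar step on the cores of compound 2 and compound 3.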